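This account rests on a few compounds, and the source may have more. Where it says the series, first, only, none or still open, it means among the compounds named here.

In a functional assay on MOLT-4 cells (Homo sapiens) for antiproliferative activity (on this read-out lower numbers stand for stronger inhibition and higher numbers for weaker inhibition), compound 1 (`COc1cc(C(=O)c2sc(-c3ccc(Cl)c(Cl)c3)cc2N)cc(OC)c1OC`) gives 270 nM with 3,4-dichlorophenyl on the shared core, compound 2 (`COc1cc(C(=O)c2sc(-c3ccc(F)cc3)cc2N)cc(OC)c1OC`) gives 12 nM with 4-fluorophenyl, and compound 3 (`COc1cc(C(=O)c2sc(-c3ccc(C)cc3)cc2N)cc(OC)c1OC`) gives 16 nM with 4-methylphenyl. Compound 3 has no separation from compound 2, as the data show a 1.3-fold higher number from compound 2 to compound 3 (0.12 log units; within the scatter) and so no order between the two. It stands well clear of compound 1, with a 17-fold lower number from compound 1 to compound 3 (1.23 log units; beyond the scatter) on this read-out.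

The next case is compound 4 (`COc1cc(C(=O)c2sc(-c3ccc(C(F)(F)F)cc3)cc2N)cc(OC)c1OC`), reached by trifluoromethyl in place of methyl on an aromatic carbon and described as trifluoromethyl in place of methyl on an aromatic carbon, para to a large group. The closest measured precedent is the exchange of fluoro and methyl at that place, which gave a 1.3-fold higher number from compound 2 to compound 3 (0.12 log units; within the scatter) as its whole effect. The other two steps, a 23-fold lower number from compound 1 to compound 2 (1.35 log units; beyond the scatter) and a 17-fold lower number from compound 1 to compound 3 (1.23 log units; beyond the scatter), show that changes to this phenyl can be large, though each also alters a second ring position. For the measured compounds named here, no measured compound carries trifluoromethyl, so the direction is uncertain. A moderate move to a higher number is expected, well short of the distance to compound 1.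

The expected step is a 2.8-fold higher number from compound 3 to compound 4 (0.45 log units; beyond the scatter) as an estimate in this assay and no more than that. For compound 4 the estimated value is 45 nM (expected range 14 nM to 200 nM).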

Compound 4, half-maximal inhibitory concentration: 250 nM
Estimate against measurement, compound 4: 5.6-fold (0.74 log units) below; measured number above the stated range.
By their numbers in this assay, from the lowest: compounds 2 and 3 (each within the scatter of the next); then compounds 4 and 1 (each within the scatter of the next).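

At this place, para to a large group, one group exchange on the ring is enough for a large step in this assay: trifluoromethyl in place of methyl gives (a 16-fold higher number from compound 3 to compound 4 (1.19 log units; beyond the scatter)) and trifluoromethyl in place of fluoro gives (a 21-fold higher number from compound 2 to compound 4 (1.32 log units; beyond the scatter)), whereas the exchange of fluoro and methyl stayed within the scatter. For the compounds shown here, the large steps seen earlier each also changed a second ring position, so compound 4 is the first case in which a change at this place alone separates the series into two levels, and it reaches the level of the 3,4-dichlorophenyl compound with no second ring substituent, with no order between the two (a 1.1-fold lower number from compound 1 to compound 4 (0.03 log units; within the scatter)). Nothing measured here bears on the reason for this step, so the result stands as an observation only.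

A single chloro at this place, as in 4-chlorophenyl, would show which level that group shares and how much of the standing of compound 1 belongs to this place. Where a methoxy, a nitrile, an amine or a longer chain such as propyl would fall relative to those two levels also remains open.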